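The source may report more compounds than this note shows. Statements on the series, on what has been measured and on what is new or still open speak of the compounds shown alone.

Measured compounds:
Compound 1, `Nc1nc(-c2ccc(Cl)cc2)c(CC(=O)O)s1`, gives > 100000 nM.
Compound 2, `COc1ccc(C(c2ccccn2)c2nc(-c3ccc(Cl)cc3)c(CC(=O)O)s2)cc1`, gives 61 nM.
Compound 3, `N#Cc1cc(-c2nc(C(c3ccc(F)cc3)c3ccc(F)cc3)sc2CC(=O)O)ccc1F`, gives 57 nM.

All three were tested in an in vitro assay on HEK385-7 cells for displacement of a labelled ligand from prostaglandin D2 receptor 2 (Homo sapiens); a higher number here means a weaker inhibitor, a lower number a stronger inhibitor. Compound 1 gives no number at all but sits at the limit of > 100000 nM in this assay, at which 1 of the 3 values shown sits. Compound 2 gives 61 nM in this assay. Compound 3 gives 57 nM, the lowest of the two numbers shown; the gap to compound 2 lies within the scatter, so neither of the two can be called stronger than the other.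

Compound 4, `Cc1cc(-c2nc(C(c3ccc(F)cc3)c3ccc(F)cc3)sc2CC(=O)O)ccn1`, has not yet been measured. It differs from compound 3 in one place: 2-methylpyridin-4-yl in place of 3-cyano-4-fluorophenyl on an aromatic carbon. Among the compounds with values here, no measured pair of compounds shows a change of this kind, so there is no step to lean on. A modest step toward a higher number is expected in this assay, one that may or may not reach beyond the scatter. Compound 4 is therefore estimated at 150 nM, with a likely range from 40 nM to 600 nM. This estimate means an expected step of a 2.6-fold higher number from compound 3 to compound 4 (0.42 log units; beyond the scatter).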

Compound 4, half-maximal inhibitory concentration: 3.1 nM
Beside the measured number, compound 4's estimate is 48-fold (1.68 log units) above it, and the stated range ends above it.
By their numbers in this assay, from the lowest: compound 4; then compounds 3 and 2 (each within the scatter of the next). At a limit, above all of these: compound 1.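

Compounds 2 and 3 differ in more than one place, so they could not show what the group on this aromatic carbon contributes on its own, next to the ring nitrogen and next to the ring atom that bears a carboxymethyl group. Replacing 3-cyano-4-fluorophenyl with 2-methylpyridin-4-yl in this assay gives an 18-fold lower number from compound 3 to compound 4 (1.26 log units; beyond the scatter) and shows that the number responds strongly to the group at this position, and that a ring with a hetero atom can stand here without any loss. Nothing measured here bears on why the number falls.

The ring nitrogen, the methyl group and the loss of the nitrile and fluorine all arrive in one change, so their shares cannot be separated. As far as these compounds go, whether unsubstituted pyridin-4-yl, or 2-methoxypyridin-4-yl, would hold the number this low remains open.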